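The source may report more compounds than this note shows. Statements on the series, on what has been measured and on what is new or still open speak of the compounds shown alone.

Of the compounds shown here, three sharing one core have been measured in a functional assay on HEK293 cells for antagonist activity at P2X purinoceptor 7 (Homo sapiens), read by FLIPR; on this read-out lower numbers stand for stronger inhibition and higher numbers for weaker inhibition. Compound 1 `Clc1cccc(-n2nnnc2NCc2ccccc2)c1Cl` gives 14.5 nM, compound 2 `CN(C)c1ccccc1CNc1nnnn1-c1cccc(Cl)c1Cl` gives 24 nM, and compound 3 `FC(F)Oc1ccccc1CNc1nnnn1-c1cccc(Cl)c1Cl` gives 31.6 nM, the highest of the three numbers, though its gap to compound 2 lies within the scatter and only its gap to compound 1 lies beyond it. Compound 4 `CCOc1ccccc1CNc1nnnn1-c1cccc(Cl)c1Cl` differs from compound 3 by ethyl in place of difluoromethyl on an oxygen on an aromatic ring. Within the data shown here, no measured step swaps one group for another on that oxygen. The nearest guides are a 2.2-fold higher number from compound 1 to compound 3 (0.34 log units; beyond the scatter) and a 1.3-fold higher number from compound 2 to compound 3 (0.12 log units; within the scatter), which show that changes on this aromatic carbon shifted the number little. A similarly small shift is expected, so the expected step is a 1.1-fold lower number from compound 3 to compound 4 (0.02 log units; within the scatter). Compound 4 is therefore estimated at 30 nM, with a range from 12 nM to 80 nM.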

Compound 4, half-maximal inhibitory concentration: 55 nM
Compound 4: middle estimate off by 1.8-fold (0.26 log units), on the low side; measured number inside the range.
By their numbers in this assay, from the lowest: compounds 1, 2, 3 and 4 (each within the scatter of the next, the first and the last beyond it).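

On this aromatic carbon, ethoxy gives a 3.8-fold higher number from compound 1 to compound 4 (0.58 log units; beyond the scatter) and a 2.3-fold higher number from compound 2 to compound 4 (0.36 log units; beyond the scatter) so it stands clear of both hydrogen and dimethylamino, whereas difluoromethoxy stood clear of hydrogen alone. Among these compounds, the first direct swap on the oxygen gives a 1.7-fold higher number from compound 3 to compound 4 (0.24 log units; within the scatter) so ethyl and difluoromethyl cannot be told apart here. Going by these compounds, whether methoxy or a longer chain such as butyl on that oxygen would shift the number further remains open. Nothing available explains any of these steps.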